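A Fluoro Substituent on the Fused Ring of Compound 2

The compounds below may be only part of what the source reports. "The series", "measured", "known", "first", "only" and "open" are said of these compounds alone.

Compound 2 `NC(=O)CNC(=O)c1cccc(-c2cccc3cc(Cc4cccc(C(F)(F)F)c4)sc23)c1` gives the higher of the two numbers measured in a functional assay on CHO cells for agonist activity at G-protein coupled receptor 52 (Homo sapiens), read by AlphaScreen and cAMP accumulation, with a stated time of 30 min; a lower number here means a smaller maximal response, a higher number a larger maximal response: compound 2 gives 102%, while compound 1 `O=C(NCCO)c1cccc(-c2cccc3cc(Cc4cccc(C(F)(F)F)c4)sc23)c1` gives 79.6%, a step that was a number 22.4 percentage points higher from compound 1 to compound 2 (beyond the scatter). Compound 3 `NC(=O)CNC(=O)c1cccc(-c2ccc(F)c3cc(Cc4cccc(C(F)(F)F)c4)sc23)c1` differs from compound 2 by fluoro in place of hydrogen on an aromatic carbon. Among the compounds with values here, the single measured step concerns the chain on the amide nitrogen and not an aromatic carbon, so no measured step bears on this change and no direction can be read from the data. A change no larger than the scatter is therefore expected, a number 4 percentage points lower from compound 2 to compound 3 (within the scatter). Compound 3 is estimated at 98%, with a range from 80% to 112%.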

Compound 3, largest response reached (Emax), in percent of the reference or control that the assay uses: 107%
Beside the measured number, compound 3's estimate is 9 percentage points below it; the measured number falls inside the stated range.
By their numbers in this assay, from the lowest: compound 1; then compounds 2 and 3 (each within the scatter of the next).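

In this assay, fluoro in place of hydrogen on this aromatic carbon, para to a large group, gives a number 5 percentage points higher from compound 2 to compound 3 (within the scatter). The maximal response therefore holds within the scatter when this position carries a fluoro substituent, a change that the earlier step on the amide chain could not address. No measurement among these data speaks to what lies behind this result.

Going by these compounds, it remains open whether a chloro, methoxy or nitrile group on the same carbon would behave alike. On these data alone, whether fluoro would do the same alongside the amide chain of compound 1 also remains open.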